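A few compounds are considered here, and "the series" means these few. Any claim that something is new, unique, unknown or untested is made for them only; others in the source may bear on it.

Compound 3 `CC(=O)N[C@H]1[C@H]([C@@H](O)[C@H](O)CNC(=O)c2ccc(Cl)cc2)O[C@@](OCc2ccc3ccccc3c2)(C(=O)O)C[C@@H]1O` gives 11600 nM in an in vitro assay on cells for binding affinity to myelin-associated glycoprotein (Mus musculus), read by surface plasmon resonance; on this read-out higher numbers stand for weaker binding and lower numbers for tighter binding. Among the three compounds measured so far, compound 3 gives the lowest number, yet both neighbours sit close to it: compound 2 `CC(=O)N[C@H]1[C@H]([C@@H](O)[C@H](O)CNC(=O)c2ccc(Cl)cc2)O[C@@](OCc2ccc(Cl)cc2)(C(=O)O)C[C@@H]1O` gives 15000 nM in this assay, and compound 1 `CC(=O)N[C@H]1[C@H]([C@@H](O)[C@H](O)CNC(=O)c2ccc(Cl)cc2)O[C@@](OCc2ccccc2)(C(=O)O)C[C@@H]1O` gives 17000 nM in this assay, so no order among the three can be claimed. The steps of a 1.5-fold lower number from compound 1 to compound 3 (0.17 log units; within the scatter) and a 1.3-fold lower number from compound 2 to compound 3 (0.11 log units; within the scatter) both replace the aromatic group on the saturated chain carbon bound to an oxygen on a saturated carbon, and both stay within the scatter, as does a 1.1-fold lower number from compound 1 to compound 2 (0.05 log units; within the scatter). Compound 4 `CC(=O)N[C@H]1[C@H]([C@@H](O)[C@H](O)CNC(=O)c2ccc(Cl)cc2)O[C@@](OCc2cccc(F)c2F)(C(=O)O)C[C@@H]1O` changes that same position once more: 2,3-difluorophenyl in place of naphthalen-2-yl on a saturated chain carbon bound to an oxygen on a saturated carbon. Among the measured compounds shown here, the earlier swaps at this position, from phenyl through 4-chlorophenyl to naphthalen-2-yl, moved the number only a little each time, and nothing among the measured compounds points to a larger move for this new group. For compound 4 the expected step is a 1.2-fold higher number from compound 3 to compound 4 (0.08 log units; within the scatter), pointing in no clear direction beyond the scatter. For compound 4 the estimated value in this assay is 14000 nM, and it is expected to fall between 7000 nM and 30000 nM.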

Compound 4, dissociation constant: 2400 nM
Compound 4: middle estimate off by 5.8-fold (0.77 log units), on the high side; measured number outside the range, below it.
By their numbers in this assay, from the lowest: compound 4; then compounds 3, 2 and 1 (each within the scatter of the next).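

In this assay the position on a saturated chain carbon bound to an oxygen on a saturated carbon proves able to move the number, for 2,3-difluorophenyl gives a 4.8-fold lower number from compound 3 to compound 4 (0.68 log units; beyond the scatter) and a 6.3-fold lower number from compound 2 to compound 4 (0.80 log units; beyond the scatter) and also a 7.1-fold lower number from compound 1 to compound 4 (0.85 log units; beyond the scatter) while every earlier swap there stayed within the scatter. Compound 4 now stands apart from the other three, which remain within the scatter of one another, so this position is not indifferent to the aromatic group it carries. Losing the second aromatic ring of naphthalen-2-yl is not enough to give this result, as compound 1 and compound 2 also carry a single six-membered aromatic ring and stay within the scatter of compound 3.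

Nothing available here explains why 2,3-difluorophenyl stands apart. The compounds shown leave open whether a single fluorine would give a similar number, and whether two chlorines in place of the two fluorines, or a pyridine ring in place of the fluorinated ring, would keep it, and they do not show how far the step holds with other changes on the shared core.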